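Series notes: aryl exchange on a ring amine nitrogen

The source may report more compounds than this note shows. Statements on the series, on what has been measured and on what is new or still open speak of the compounds shown alone.

Measured so far:
Compound 1 `Nc1ccccc1NC(=O)c1ccc(CSC(=S)N2CCN(c3ccc(Cl)cc3)CC2)cc1` gives 15% in a functional assay on MGC-803 cells (Homo sapiens) for antiproliferative activity, read by CCK-8 assay, with a stated time of 72 h, tested at 2 uM; on this read-out higher numbers stand for a stronger effect at the one concentration tested and lower numbers for a weaker effect.
Compound 2 `Nc1ccccc1NC(=O)c1ccc(CSC(=S)N2CCN(c3cccnc3)CC2)cc1` gives 27.6% in this assay.

Among the measured compounds shown here, compound 2 holds the higher of the two numbers in this assay; its only neighbour is compound 1, and the step of a number 12.6 percentage points higher from compound 1 to compound 2 (beyond the scatter) lies beyond the scatter.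

Compound 3 `N#Cc1ccc(N2CCN(C(=S)SCc3ccc(C(=O)Nc4ccccc4N)cc3)CC2)cc1` is not yet measured. It differs from compound 2 as follows: 4-cyanophenyl in place of pyridin-3-yl on an amine nitrogen in a ring. For the measured compounds named here, only one measured step bears on this change, namely a number 12.6 percentage points higher from compound 1 to compound 2 (beyond the scatter), which replaced 4-chlorophenyl on the ring amine nitrogen by pyridin-3-yl. The present change goes the other way in the sense that an all-carbon aromatic ring returns, but with a nitrile in place of the chlorine, so that step is a rough guide at best. A modest move downward toward the level of compound 1 is expected, though not beyond the scatter with confidence, so the expected step is a number 6.6 percentage points lower from compound 2 to compound 3 (within the scatter). Compound 3 is therefore estimated at 21% in this assay, with a range from 8% to 35%.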

Compound 3, a percentage reported as inhibition, at one concentration (the size of the read-out at that concentration, not a potency): 34.5%
The estimate for compound 3 lay 13.5 percentage points below the measured number, and the stated range covers the measured number.
By their numbers in this assay, from the lowest: compound 1; then compounds 2 and 3 (each within the scatter of the next).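

In this assay, the result a number 6.9 percentage points higher from compound 2 to compound 3 (within the scatter) means that 4-cyanophenyl and pyridin-3-yl on the ring amine nitrogen cannot be told apart, so a ring of carbon only at this position does not by itself bring the read-out back to the level of compound 1. Among the compounds shown here, the new comparison keeps the carbon-only ring and changes only its substituent: cyano in place of chloro on an aromatic carbon gives a number 19.5 percentage points higher from compound 1 to compound 3 (beyond the scatter), so the group carried by that ring matters on this read-out, and a ring nitrogen is not the only change at this position that separates a compound from compound 1. No measurement at hand gives a reason for either step.

The compounds shown leave open how an unsubstituted phenyl ring, a methoxy group or a carboxylic acid in place of the nitrile would compare, and whether a pyridin-4-yl ring would match pyridin-3-yl. Since each number is a reading at one concentration, they also leave open whether the gap between the chloro and cyano compounds would hold across a range of concentrations.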